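A few compounds are considered here, and "the series" means these few. Any claim that something is new, unique, unknown or untested is made for them only; others in the source may bear on it.

Measured so far:
compound 1, `Cc1cccc(Oc2cccc(CN3CCC(n4cc(C)c(=O)[nH]c4=O)CC3)c2)c1`: > 64000 nM
compound 2, `Cc1cn(C2CCN(Cc3cccc(Oc4cc(C(F)(F)F)cc(C(F)(F)F)c4)c3)CC2)c(=O)[nH]c1=O`: "not determined" (no result reported)

In an ADME assay on MRC5 cells (Homo sapiens) for cytotoxicity, read by fluorescence and resazurin assay, with a stated time of 3 days (a higher number here means a weaker inhibitor, a lower number a stronger inhibitor), compound 1 gives > 64000 nM, which is a limit of the assay and not a number. Compound 2 was also entered in this assay, but for it the result is "not determined" (no result reported). Among the measured compounds shown here, compound 1 therefore stands at the limit of > 64000 nM in this assay, at which 1 of the 2 values shown sits, and there is no pair of measured compounds from which a step could be read.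

Compound 3, `Cc1cn(C2CCN(Cc3cccc(Oc4cc(F)cc(F)c4)c3)CC2)c(=O)[nH]c1=O`, is not yet measured in this assay. It differs from compound 1 in one place: 3,5-difluorophenyl in place of 3-methylphenyl on an oxygen on an aromatic ring. With compound 1 at a limit and nothing measured on this kind of change, the size of the step cannot be taken from the data. The working expectation is a step of no size beyond the scatter, in neither direction, so that compound 3 is most likely again returned as a limit. Compound 3 is estimated at 64000 nM in this assay, with a range from 30000 nM to 150000 nM. This estimate means an expected step of a number no higher from compound 1 to compound 3 (the limit leaves the size open), within the scatter.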

Compound 3, half-maximal inhibitory concentration: > 64000 nM
Compound 3: only a limit was reported; the forecaster's own chance of this, stated with the estimate: 70%; the middle value lies on the limit itself.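

In this assay compound 3 gives > 64000 nM as a limit of the assay and not a number. Among the compounds shown here, compound 1 also stands at a limit, so no step between compound 1 and compound 3 can be read: the limit of > 64000 nM in this assay, at which 2 of the 3 values shown sit. Left open is whether 3,5-difluorophenyl in place of 3-methylphenyl on an oxygen on an aromatic ring changes this read-out at all.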